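The source may report more compounds than this note shows. Statements on the series, on what has been measured and on what is new or still open speak of the compounds shown alone.

Going by the values given here, compound 2 `Cc1ccccc1C(=O)Nc1ccc(S(=O)(=O)NC2CCN(C(=O)N3CCC3)CC2)c2ccccc12` gives 3.5 nM in an assay on L1.2 cells for binding affinity to C-C chemokine receptor type 8 (Homo sapiens) (a lower number here means a stronger inhibitor, a higher number a weaker inhibitor), the lower of the two numbers measured so far; compound 1 `CCCNC(=O)N1CCC(NS(=O)(=O)c2ccc(NC(=O)c3ccccc3C)c3ccccc23)CC1` gives 77.4 nM in this assay. Among the compounds with values here, the only step yet measured, a 22-fold lower number from compound 1 to compound 2 (1.34 log units; beyond the scatter), sits at the same carbonyl carbon. Compound 3 `CCN(CC)CCCC(=O)N1CCC(NS(=O)(=O)c2ccc(NC(=O)c3ccccc3C)c3ccccc23)CC1` differs from compound 2 by 3-(diethylamino)propyl in place of azetidin-1-yl on a carbonyl carbon. Within the data shown here, no measured step covers this change, and the one step at this carbonyl carbon shows that it matters. Compound 3 is therefore expected to give 15 nM in this assay, between 3 nM and 80 nM. The expected step of a 4.3-fold higher number from compound 2 to compound 3 (0.63 log units; beyond the scatter) is a modest loss.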

Compound 3, inhibition constant: 567 nM
Estimate against measurement, compound 3: 38-fold (1.58 log units) below; the measured number lies above the stated range.
By their numbers in this assay, from the lowest: compound 2; then compound 1; then compound 3.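

In this assay, going by these compounds alone, this carbonyl carbon turns out to be more sensitive than the one earlier step showed: 3-(diethylamino)propyl in place of azetidin-1-yl gives a 160-fold higher number from compound 2 to compound 3 (2.21 log units; beyond the scatter). The same group in place of propylamino gives a 7.3-fold higher number from compound 1 to compound 3 (0.86 log units; beyond the scatter), so of the three groups here, azetidin-1-yl gives the lowest number and 3-(diethylamino)propyl the highest. No measurement shown accounts for this loss. Going by these compounds, whether the loss follows the chain length or the terminal amine remains open; a pyrrolidin-1-yl group or a shorter chain ending in dimethylamino at this carbonyl carbon would bear on that.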